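Enantiomer Swap at the Piperazine Ring Carbon

A few compounds are considered here, and "the series" means these few. Any claim that something is new, unique, unknown or untested is made for them only; others in the source may bear on it.

Measured so far:
Compound 1, `CC[C@@H]1CN(c2ccc(C(=O)Nc3cn4cc(C)nc4cn3)c(F)c2)CCN1`: 3730 ng.h/mL
Compound 2, `Cc1cn2cc(NC(=O)c3ccc(N4CCNC(C)C4)cc3F)nc2c(C)n1`: 3900 ng.h/mL

Both compounds were tested in an ADME assay on the whole organism (strain FVB) for pharmacokinetics, with Mus musculus as the target, read by LC-MS, with a stated time of 10 days, at a dose of 3 mg/kg by the intraperitoneal route; a lower number here means less compound in the circulation, a higher number more compound in the circulation at the dose given. Compound 1 gives 3730 ng.h/mL and compound 2 gives 3900 ng.h/mL. Compound 1 has the lowest of the two numbers, but the gap to compound 2 lies within the scatter, so the two cannot be told apart on these figures. Going by the values given here, no step between the two compounds is recorded, since they differ in more than one place.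

The new compound, compound 3, `CC[C@H]1CN(c2ccc(C(=O)Nc3cn4cc(C)nc4cn3)c(F)c2)CCN1`, is the mirror image of compound 1 at one centre: the two compounds have the same atoms and bonds and differ only in configuration as drawn: 1 of 1 stereo elements differ; a stereocentre at a saturated ring carbon is drawn R in compound 1 and S in compound 3. Nothing is known from the two measured compounds about how a change of configuration alone plays out in this assay. With no shown step to lean on, the expected step from compound 1 to compound 3, a 1.1-fold lower number from compound 1 to compound 3 (0.03 log units; within the scatter), is small and without a preferred direction, likely within the scatter. Compound 3 is therefore expected to give about 3500 ng.h/mL, with a range from 1700 ng.h/mL to 7200 ng.h/mL.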

Compound 3, area under the concentration-time curve: 4450 ng.h/mL
Compound 3: middle estimate off by 1.3-fold (0.10 log units), on the low side; the range from low to high includes it.
By their numbers in this assay, from the lowest: compounds 1, 2 and 3 (each within the scatter of the next).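

Going by these compounds alone, the step in this assay is the first here that changes one thing only, and it isolates the stereocentre at the saturated ring carbon: the fact that compounds 1 and 3 differ only in the configuration as drawn. Redrawing this carbon from R to S gives a 1.2-fold higher number from compound 1 to compound 3 (0.08 log units; within the scatter), so the two mirror-image forms cannot be told apart on this read-out. At this position, then, configuration alone produces no readable change in the amount of compound in the circulation at the dose given, and neither form can be preferred on these figures.

Going by these compounds, what stays open is whether this holds for other groups at the same stereocentre, such as a propyl chain or a hydroxymethyl group. Also open, on these data alone, is how compound 2, whose ring carbon is drawn without a configuration, relates to either form.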